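The source may report more compounds than this note shows. Statements on the series, on what has been measured and on what is new or still open speak of the compounds shown alone.

Compounds measured in a functional assay on MCF7 cells (Homo sapiens) for antiproliferative activity, read by MTT assay, with a stated time of 72 h; on this read-out higher numbers stand for weaker inhibition and lower numbers for stronger inhibition

- Compound 1 `COc1cc(-n2ncnc2-c2ccc(C)cc2)cc(OC)c1OC` gives 540 nM
- Compound 2 `CCOc1ccc(-c2ncnn2-c2cc(OC)c(OC)c(OC)c2)cc1` gives 50 nM
- Compound 3 `COc1cc(-n2ncnc2-c2ccccc2)cc(OC)c1OC` gives > 10000 nM

Compound 3 stands at > 10000 nM in this assay, and this is a limit of the assay, not a number. Compound 4 `COc1cc(-n2ncnc2-c2ccc(OC(C)C)cc2)cc(OC)c1OC` differs from compound 3 by a single change, isopropoxy in place of hydrogen on an aromatic carbon.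

Among the compounds with values here, three measured steps bear on this change. Hydrogen in place of methyl gives an at least 18-fold higher number from compound 1 to compound 3 (1.26 log units; beyond the scatter), and hydrogen in place of ethoxy gives an at least 200-fold higher number from compound 2 to compound 3 (2.30 log units; beyond the scatter). Ethoxy in place of methyl gives an 11-fold lower number from compound 1 to compound 2 (1.03 log units; beyond the scatter). All three are large and beyond the scatter, and among these three compounds none goes against the link between hydrogen on this carbon and the weakest inhibition. Isopropoxy itself has not been measured. The nearest measured case is compound 2, with ethoxy on that carbon, at 50 nM, so a large step towards stronger inhibition is expected in this assay. The expected step is an at least 66-fold lower number from compound 3 to compound 4 (1.82 log units; beyond the scatter). For compound 4 the estimated value is 150 nM, with an expected range of 30 nM to 1200 nM.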

Compound 4, half-maximal inhibitory concentration: 610 nM
Compound 4: the middle estimate sits 4.1-fold (0.61 log units) below what was measured, and the stated range covers the measured number.
By their numbers in this assay, from the lowest: compound 2; then compounds 1 and 4 (each within the scatter of the next). At a limit, above all of these: compound 3.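

For compound 3 the value is a limit of the assay and not a number: the limit of > 10000 nM in this assay, at which 1 of the 4 values shown sits. In this assay, isopropoxy on this aromatic carbon, para to a large group, gives an at least 16-fold lower number from compound 3 to compound 4 (1.21 log units; beyond the scatter), so a third group at this place, after methyl and ethoxy, stands clear of hydrogen. The response does not simply follow the size of the group, however: methyl in place of hydrogen on the saturated chain carbon bound to the oxygen gives a 12-fold higher number from compound 2 to compound 4 (1.09 log units; beyond the scatter), and isopropoxy in place of methyl gives a 1.1-fold higher number from compound 1 to compound 4 (0.05 log units; within the scatter), which leaves compound 1 and compound 4 level and ethoxy alone among the three groups distinct.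

The compounds shown leave open where a methoxy, a propoxy, a longer chain or an amine on this carbon would fall in this assay. From the compounds shown here alone, whether the rise from ethoxy to isopropoxy goes with branching of the chain or with its length also stays open, as does how the same changes would read in other cells.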